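A few compounds are considered here, and "the series" means these few. Any claim that something is new, unique, unknown or untested is made for them only; others in the source may bear on it.

Among the three compounds measured here, compound 3 `Cc1ccc(S(=O)(=O)N2C=CNC(=O)[C@H]2CC(=O)NC2CCCCC2)cc1` stands highest: in an in vitro functional assay on cells for antagonist activity at B1 bradykinin receptor (Homo sapiens), read by luminescence and calcium flux, with a stated time of 2 h (on this read-out higher numbers stand for weaker inhibition and lower numbers for stronger inhibition), compound 3 gives 990 nM, whereas compound 1 `Cc1ccc(S(=O)(=O)N2C=CNC(=O)[C@H]2CC(=O)N[C@@H]2CCCc3ccccc32)cc1` gives 3.3 nM and compound 2 `Cc1ccc(S(=O)(=O)N2C=CNC(=O)[C@H]2CC(=O)NC2CCNc3ccccc32)cc1` gives 21.6 nM. The step of a 300-fold higher number from compound 1 to compound 3 (2.48 log units; beyond the scatter) and the step of a 46-fold higher number from compound 2 to compound 3 (1.66 log units; beyond the scatter) both run toward higher numbers, and the step of a 6.5-fold higher number from compound 1 to compound 2 (0.82 log units; beyond the scatter) separates the two lower members. All three differ only in the group carried on the amide-type nitrogen of the shared core.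

Compound 4 `Cc1ccc(S(=O)(=O)N2C=CNC(=O)[C@H]2CC(=O)NC2CCOCC2(C)C)cc1` carries on that same nitrogen (a group of 8 heavy atoms (7 carbon, 1 oxygen; one six-membered non-aromatic ring with 1 hetero atom) in place of a group of 6 heavy atoms (6 carbon; one six-membered non-aromatic ring of carbon only), on an amide-type nitrogen). Within the data shown here, no measured step exchanges one six-membered non-aromatic ring for another on this nitrogen; the two large steps into compound 3 instead remove a group holding a six-membered aromatic ring, and compound 4, like compound 3, has no such aromatic ring. The incoming group differs from cyclohexyl by its one hetero atom and the additional carbons, but nothing measured tells how much those matter. Compound 4 is therefore expected to remain in the region of compound 3, with a step of a 1.1-fold higher number from compound 3 to compound 4 (0.05 log units; within the scatter) in this assay that may well lie within the scatter. The estimate for compound 4 is 1100 nM, with a range from 300 nM to 4000 nM.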

Compound 4, half-maximal inhibitory concentration: 25.2 nM
Compound 4: middle estimate off by 44-fold (1.64 log units), on the high side; measured number below the stated range.
By their numbers in this assay, from the lowest: compound 1; then compounds 2 and 4 (each within the scatter of the next); then compound 3.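

In this assay, among these compounds, the step of a 39-fold lower number from compound 3 to compound 4 (1.59 log units; beyond the scatter) shows that a six-membered aromatic ring is not required on the amide-type nitrogen for a low number, as the entering group has only one six-membered non-aromatic ring with one hetero atom, whereas the earlier low numbers belonged only to groups holding an aromatic ring. The step of a 1.2-fold higher number from compound 2 to compound 4 (0.07 log units; within the scatter) lies within the scatter, so this smaller group without an aromatic ring matches the group of compound 2 on this read-out, while the step of a 7.6-fold higher number from compound 1 to compound 4 (0.88 log units; beyond the scatter) lies beyond the scatter and leaves the 1,2,3,4-tetrahydronaphthalen-1-yl group of compound 1 with the lowest number. No accompanying data bear on why this change has so large an effect.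

The compounds shown do not separate the contribution of the ring oxygen from that of the additional carbons, a question that an unsubstituted tetrahydropyranyl group on the same nitrogen would address. They also leave open how a piperidinyl ring, with an amine in place of the ring oxygen, would stand in this series.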